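The source may report more compounds than this note shows. Statements on the series, on what has been measured and on what is new or still open speak of the compounds shown alone.

In a functional assay on PC-3 cells (Homo sapiens) for cytotoxicity, read by sulforhodamine B assay, with a stated time of 72 h (on this read-out lower numbers stand for stronger inhibition of growth and higher numbers for weaker inhibition of growth), compound 3 `O=C(Nc1ccccc1C(F)(F)F)C1CCc2ccccc2N1C(=O)c1ccccc1` gives 5560 nM, the lowest of the two plain numbers recorded here. Compound 2 `O=C(Nc1ccccc1C(F)(F)F)C1CCc2ccccc2N1` gives 53300 nM, and the gap between them is a 9.6-fold lower number from compound 2 to compound 3 (0.98 log units; beyond the scatter). Compound 1 `CCCC(=O)N1c2ccccc2CCC1C(=O)Nc1ccccc1C(F)(F)F` gives only a limit of the assay, > 70000 nM. Compound 4 `CC(=O)N1c2ccccc2CCC1C(=O)Nc1ccccc1C(F)(F)F` differs from compound 3 by methyl in place of phenyl on a carbonyl carbon. Among the compounds with values here, two measured steps bear on this change: an at least 12-fold lower number from compound 1 to compound 3 (1.10 log units; beyond the scatter) and a 9.6-fold lower number from compound 2 to compound 3 (0.98 log units; beyond the scatter), each a gain when the phenyl arrives on that carbonyl carbon. Taking the phenyl away again is therefore expected to cost potency, and the step is estimated as a 7.2-fold higher number from compound 3 to compound 4 (0.86 log units; beyond the scatter). Compound 4 is estimated at 40000 nM, within a range from 10000 nM to 150000 nM, with a real chance that only a limit is reported.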

Compound 4, concentration for 50% growth inhibition: > 80000 nM
Compound 4: only a limit was reported; the forecaster's own chance of this, stated with the estimate: 35%; middle value at least 2.0-fold (0.30 log units) away from the limit.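

In this assay, methyl in place of phenyl on the carbonyl carbon gives an at least 14-fold higher number from compound 3 to compound 4 (1.15 log units; beyond the scatter), so a small acyl group does not retain the gain seen with benzoyl. Acetyl in place of hydrogen on the ring nitrogen gives an at least 1.5-fold higher number from compound 2 to compound 4 (0.17 log units; that floor lies within the scatter), which shows no gain from acylation alone. Compound 1 and compound 4 each give only a limit of the assay, so the step between them cannot be read.

From the compounds shown here alone, what cyclohexyl or a pyridine ring on that carbonyl carbon would give stays open, as does whether the gain requires an aromatic ring there.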